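Thiazolyl in place of phenyl on the sulfonyl of compound 2

This account rests on a few compounds, and the source may have more. Where it says the series, first, only, none or still open, it means among the compounds named here.

compound 1 `CCCCc1ccc(CN(c2ccccc2CCCC(=O)O)S(C)(=O)=O)cc1` — 103 nM
compound 2 `CC(C)(C)c1ccc(CN(Cc2cccc(CCC(=O)O)c2)S(=O)(=O)c2ccccc2)cc1` — 0.2 nM

In a functional assay on HEK293 cells for agonist activity at prostaglandin E2 receptor EP2 subtype (Rattus norvegicus), read by cAMP accumulation (a lower number here means that less compound is needed, a higher number that more compound is needed for the effect), compound 1 gives 103 nM, and compound 2 gives 0.2 nM. Compound 2 thus stands at the lowest of the two numbers, and compound 1 lies above it by a gap far beyond the usual scatter. Compound 3 `CC(C)(C)c1ccc(CN(Cc2cccc(CCC(=O)O)c2)S(=O)(=O)c2nccs2)cc1` has not yet been measured in this assay. It differs from compound 2 in one place: 1,3-thiazol-2-yl in place of phenyl on a sulfonyl sulfur. Among the measured compounds shown here, no pair of measured compounds differs by this change alone, so no measured step sets its size. Compound 1 and compound 2 differ in several places at once, and their two values show only that a wide gap separates them. The expectation for compound 3 therefore rests on the change itself, 1,3-thiazol-2-yl in place of phenyl on the sulfonyl sulfur, with the rest of compound 2 kept unchanged. The step of a 2.5-fold higher number from compound 2 to compound 3 (0.40 log units; beyond the scatter) is expected to be modest, a slight rise that may not exceed the scatter. Compound 3 is accordingly estimated at 0.5 nM, with a range from 0.1 nM to 3 nM.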

Compound 3, half-maximal effective concentration: 1.1 nM
The estimate for compound 3 lay 2.2-fold (0.34 log units) below the measured number; low and high end bracket the measured number.
By their numbers in this assay, from the lowest: compound 2; then compound 3; then compound 1.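

In this assay, the sulfonyl sulfur, whose other neighbour is the sulfonamide nitrogen, now has its first measured step: putting 1,3-thiazol-2-yl in place of phenyl gives a 5.5-fold higher number from compound 2 to compound 3 (0.74 log units; beyond the scatter). The step is modest but lies beyond the scatter, so this position does respond to the identity of the ring, although the swap to a five-membered aromatic ring with 2 hetero atoms still leaves compound 3 at 1.1 nM, a low number on this scale. No measurement among the data shown accounts for the rise, and the size of the step remains an observation without an explanation.

This single swap changes ring size and hetero atoms together, so the compounds shown leave open which of these goes with the rise; a thiophen-2-yl ring, which keeps the five-membered ring and sulfur without the nitrogen, and a pyridin-2-yl ring, which keeps the six-membered ring and adds a nitrogen, would pull the two apart. Also open, on these data alone, is whether the same step would hold with the rest of the molecule changed, for instance with an amine on the thiazole ring.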